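Hexyloxy in place of methoxy at the assay limit

The source may report more compounds than this note shows. Statements on the series, on what has been measured and on what is new or still open speak of the compounds shown alone.

- compound 1 `O=C1OC(Cc2nc(-c3ccccc3)no2)c2ccccc21` gives > 10000 nM as a limit in a functional assay on RAW264.7 cells (Mus musculus) for inhibition, read by Griess assay, with stated times of 1 h and 24 h; a lower number here means a stronger inhibitor, a higher number a weaker inhibitor
- compound 2 `O=C1OC(Cc2nc(Cc3ccccc3)no2)c2ccccc21` gives > 10000 nM as a limit in this assay
- compound 3 `COc1ccc(C(O)C2OC(=O)c3c(OC)cc(OC)cc32)cc1` gives > 10000 nM as a limit in this assay

Compound 3 stands on the limit of > 10000 nM in this assay, at which 3 of the 3 values shown sit, and so offers a limit, not a number, to start from. Compound 4 `CCCCCCOc1ccc(C(O)C2OC(=O)c3c(OC)cc(OC)cc32)cc1` carries pentyl in place of hydrogen on a saturated chain carbon bound to an oxygen on an aromatic ring and thereby turns methoxy into hexyloxy. Within the data shown here, the only measured step, a step that the two limits leave unreadable from compound 1 to compound 2, is a different change and gives no size to carry over. No step beyond the scatter is therefore expected in this assay, and no direction can be favoured. The expected step, a number no higher from compound 3 to compound 4 (the limit leaves the size open), rests on no readable precedent. For compound 4 the estimated value is 10000 nM (range 3000 nM to 30000 nM).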

Compound 4, half-maximal inhibitory concentration: 5360 nM
Beside the measured number, compound 4's estimate is 1.9-fold (0.27 log units) above it, and the stated range covers the measured number.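

In this assay the change of methoxy to hexyloxy gives an at least 1.8-fold lower number from compound 3 to compound 4 (0.27 log units; that floor lies within the scatter), and the true size of the step stays unread beyond that floor. Compound 4 is the only compound shown with a number and not a limit, so this position now has a readable value to work from: the limit of > 10000 nM in this assay, at which 3 of the 4 values shown sit. This single step supports no pattern along the chain.

From the compounds shown here alone, whether a shorter butoxy chain, a longer chain or an amine at the end of the hexyl chain would shift the number remains open. Going by these compounds, whether hexyloxy would have any effect on the core of compound 1 also remains open.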